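Trading Two Chlorines for One Fluorine on an Amide

The compounds below may be only part of what the source reports. "The series", "measured", "known", "first", "only" and "open" are said of these compounds alone.

Going by the values given here, compound 1 `CN(C)c1nc(N[C@H]2CC[C@@H](NC(=O)c3ccc(Cl)c(Cl)c3)CC2)nc2ccccc12` is one of two compounds measured in an assay on HEK293 cells for inhibition of melanin-concentrating hormone receptor 1 (Homo sapiens), read by radioligand binding; a higher number here means a weaker inhibitor, a lower number a stronger inhibitor. In this assay compound 1 gives 5 nM, the lower of the two numbers recorded. The other compound, compound 2 `CN(C)c1nc(NCC2CCC(CNC(=O)c3ccc(Br)cc3OC(F)(F)F)CC2)nc2ccccc12`, gives 1500 nM in this assay, and the gap between the two lies far beyond the usual scatter, so compound 1 is clearly the stronger inhibitor of the pair. Among the compounds with values here, compound 2 differs from compound 1 in several places at once, so no single structural step has yet been measured.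

Compound 3 `CN(C)c1nc(N[C@H]2CC[C@@H](NC(=O)c3cccc(F)c3)CC2)nc2ccccc12` has not yet been measured. It differs from compound 1 in only one place: 3-fluorophenyl in place of 3,4-dichlorophenyl on a carbonyl carbon. The shared core of compound 1 and everything else around the amide stays as it is. Within the data shown here, no measured step is available to guide the size of this change, so the expectation is a judgement rather than a reading of the data. Compound 3 is expected to be a weaker inhibitor than compound 1, with a 12-fold higher number from compound 1 to compound 3 (1.08 log units; beyond the scatter) a step upward beyond the scatter. In this assay compound 3 is estimated at 60 nM, with a likely range from 10 nM to 400 nM.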

Compound 3, half-maximal inhibitory concentration: 9.5 nM
Estimate against measurement, compound 3: 6.3-fold (0.80 log units) above; the whole stated range lies above it.
By their numbers in this assay, from the lowest: compounds 1 and 3 (each within the scatter of the next); then compound 2.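

Going by these compounds alone, this is the first change in a single place to be measured, and it shows that this position on the amide accepts a clear change in substituents: replacing 3,4-dichlorophenyl with 3-fluorophenyl on the carbonyl carbon gives a 1.9-fold higher number from compound 1 to compound 3 (0.28 log units; within the scatter) in this assay. Within the usual scatter, the two compounds cannot be told apart, even though both chlorine atoms leave, one fluorine enters, and the group loses one heavy atom overall. For this pair, then, keeping the 3,4-dichloro pattern is not needed for a low nanomolar number, although no measurement available here explains why the swap makes so little difference.

Because the two chlorines leave and the fluorine enters in one step, the separate contribution of each atom remains unresolved, and a single step cannot show how much further this position can be changed. Going by these compounds, it remains open whether a plain phenyl group with no substituent, or a phenyl ring carrying a methoxy group or a nitrile, would stay within the scatter of compound 1 in this assay.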